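This account rests on a few compounds, and the source may have more. Where it says the series, first, only, none or still open, it means among the compounds named here.

Measured compounds in a functional assay on DLD-1 cells (Homo sapiens) for cytotoxicity, with a stated time of 48 h (on this read-out lower numbers stand for stronger inhibition and higher numbers for weaker inhibition), are these
- compound 1 `CC(C)COc1ccc2oc(/C=C/[S+](C)[O-])cc(=O)c2c1` gives 5000 nM
- compound 2 `Cc1ccc2oc(/C=C/[S+](C)[O-])cc(=O)c2c1` gives 7000 nM
- compound 3 `C[S+]([O-])/C=C/c1cc(=O)c2cc(Cl)ccc2o1` gives 6500 nM

Compound 3 at 6500 nM cannot be separated from the other two members of the series. The step to it from the isobutoxy member is a 1.3-fold higher number from compound 1 to compound 3 (0.11 log units; within the scatter), and the step to it from the methyl member is a 1.1-fold lower number from compound 2 to compound 3 (0.03 log units; within the scatter).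

The next member is compound 4 `C[S+]([O-])/C=C/c1cc(=O)c2cc(OC(=O)C(C)(C)C)ccc2o1`, where ((tert-butyl)carbonyl)oxy stands in place of chloro on an aromatic carbon: ((tert-butyl)carbonyl)oxy in place of chloro on an aromatic carbon.

Going by the values given here, three measured steps bear on this exchange, since each also swaps one group on an aromatic carbon of the shared core. Besides the two above, there is a 1.4-fold higher number from compound 1 to compound 2 (0.15 log units; within the scatter). All three are small, and none leaves the scatter. Across isobutoxy, methyl and chloro, this assay has so far shown no response to this kind of exchange, and no compound goes against that within these three. Among the compounds with values here, no measured compound carries ((tert-butyl)carbonyl)oxy, so this group itself remains untested, and the range has to stay wide.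

No step beyond the scatter is expected, in either direction. The estimated step is a 1.1-fold lower number from compound 3 to compound 4 (0.03 log units; within the scatter). For compound 4 the estimated value is 6000 nM, with an expected range from 2500 nM to 13000 nM.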

Compound 4, half-maximal inhibitory concentration: 8000 nM
Compound 4: the middle estimate sits 1.3-fold (0.12 log units) below what was measured; the measured number falls inside the stated range.
By their numbers in this assay, from the lowest: compounds 1, 3, 2 and 4 (each within the scatter of the next).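

In this assay, the aromatic carbon of the shared core takes ((tert-butyl)carbonyl)oxy, with 7 heavy atoms and 2 hydrogen-bond acceptors, in place of chloro, with 1 heavy atom and no acceptor, and the result stays within the scatter (a 1.2-fold higher number from compound 3 to compound 4 (0.09 log units; within the scatter)). The exchange for methyl at the same carbon reads the same way (a 1.1-fold higher number from compound 2 to compound 4 (0.06 log units; within the scatter)), so the flat response seen among the small and mid-sized groups now extends to a group carrying a carbonyl. Going by these compounds alone, the step on the oxygen, with (tert-butyl)carbonyl in place of isobutyl, also stays within the scatter (a 1.6-fold higher number from compound 1 to compound 4 (0.20 log units; within the scatter)), so all four compounds remain inseparable on this read-out, and no compound goes against the flat picture.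

On these data alone, whether an amine, a carboxylic acid or a substituent with a ring of its own on this carbon would give a step beyond the scatter remains open, as does any change to the methyl sulfinyl-bearing side of the core. No evidence is available on why the read-out stays flat across these groups.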